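The source may report more compounds than this note shows. Statements on the series, on what has been measured and on what is new or still open speak of the compounds shown alone.

Within the data shown here, compound 2 `Cc1ccc(OCC(=O)N(Cc2cccs2)C(C)C)cc1` is the only member of this small set with a numerical result: in an assay on HEK293 cells for agonist activity at transient receptor potential cation channel subfamily M member 8 (Homo sapiens), read by fluorescence and calcium flux, with a stated time of 15 min (a lower number here means that less compound is needed, a higher number that more compound is needed for the effect), compound 2 gives 70 nM. Compound 1 `CCN(Cc1ccncc1)C(=O)COc1ccc(C)cc1` is recorded in this assay as "not active" (no number reported), so no number stands beside it for comparison. Compound 3 `Cc1ccc(OCC(=O)N(Cc2cccs2)c2cnccn2)cc1` differs from compound 2 by pyrazin-2-yl in place of isopropyl on an amide-type nitrogen. Among the measured compounds shown here, with no measured step of comparable kind to draw on, the expected step of a 2.9-fold higher number from compound 2 to compound 3 (0.46 log units; beyond the scatter) is a moderate loss, somewhat beyond the usual scatter. Compound 3 is therefore estimated at 200 nM in this assay, within a range of 50 nM to 1000 nM.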

Compound 3, half-maximal effective concentration: 1240 nM
Compound 3: middle estimate off by 6.2-fold (0.79 log units), on the low side; measured number above the stated range.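

On the amide-type nitrogen, pyrazin-2-yl in place of isopropyl gives an 18-fold higher number from compound 2 to compound 3 (1.25 log units; beyond the scatter) in this assay and so shows that the group at this position can shift the number strongly. Compound 3 still gives 1240 nM and thus retains a measurable response with this six-membered aromatic ring in place. Nothing available explains the size of this step.

The compounds shown leave open whether the change in number follows the ring itself or its ring nitrogens. They also do not show how phenyl, pyridin-2-yl, methyl or a longer chain would behave at this nitrogen.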